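The source may report more compounds than this note shows. Statements on the series, on what has been measured and on what is new or still open speak of the compounds shown alone.

Compound 1 `C=C(CC)C(=O)c1ccc(OCC(=O)NCCO)c(Cl)c1Cl`: in a functional assay on CLL cells (Homo sapiens) for cytotoxicity, read by MTT assay, with a stated time of 48 h (on this read-out lower numbers stand for an effect already at smaller amounts and higher numbers for an effect only at larger amounts of compound), compound 1 gives > 25000 nM, which is a limit of the assay and not a number.
Compound 2 `C=C(CC)C(=O)c1ccc(OCC(=O)Nc2ccc(C(=O)O)cc2)c(Cl)c1Cl`: in this assay compound 2 gives 5000 nM.
Compound 3 `C=C(CC)C(=O)c1ccc(OCC(=O)NCC(=O)O)c(Cl)c1Cl`: in this assay compound 3 gives > 25000 nM, again a limit and not a number.

Among the compounds with values here, compound 2 therefore stands alone as the one compound with a measured number, while the other two sit at the limit of > 25000 nM in this assay, at which 2 of the 3 values shown sit. Compound 4 `C=C(CC)C(=O)c1ccc(OCC(=O)Nc2ccc(S(=O)(=O)O)cc2)c(Cl)c1Cl` differs from compound 2 in one place: sulfo in place of carboxy on an aromatic carbon.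

The measured steps all exchange the whole group on the amide-type nitrogen: an at least 5.0-fold lower number from compound 1 to compound 2 (0.69 log units; beyond the scatter) and an at least 5.0-fold higher number from compound 2 to compound 3 (0.69 log units; beyond the scatter). Both run between a number and a limit, and both replace the full substituent, so they say little about swapping one acidic group for another while the 4-substituted phenyl ring stays in place. Within the data shown here, no measured step exchanges the acid group itself.

With that, compound 4 is expected to stay close to compound 2, an estimated 1.2-fold higher number from compound 2 to compound 4 (0.08 log units; within the scatter) that lies within the scatter. The estimate for compound 4 is 6000 nM, with a range from 2500 nM to 15000 nM.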

Compound 4, half-maximal effective concentration: > 25000 nM
Compound 4: a limit, no number; the forecaster's own chance of this, stated with the estimate: 15%; at least 4.1-fold (0.61 log units) between middle value and limit.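

Within the data shown here, with the aromatic ring kept in place, this result exchanges only the group on that ring's carbon, which no earlier step did: sulfo in place of carboxy gives an at least 5.0-fold higher number from compound 2 to compound 4 (0.69 log units; beyond the scatter) in this assay. At this position, then, sulfo does not stand in for carboxy, and among the compounds shown only compound 2, with its carboxy, gives a measured number. The value of compound 4 is a limit of the assay and not a number, and it is not alone there: the limit of > 25000 nM in this assay, at which 3 of the 4 values shown sit.

Going by these compounds, whether a methyl ester, a primary amide or an amine on the same aromatic carbon would give a measured number remains open. Among these compounds, the single exchange also does not show which difference between sulfo and carboxy matters here.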